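A trifluoromethoxy swap on compound 3

A few compounds are considered here, and "the series" means these few. Any claim that something is new, unique, unknown or untested is made for them only; others in the source may bear on it.

- Compound 1 `CN1c2ccc(NC(=S)Nc3ccc(C(F)(F)F)cc3)cc2C(C)(C)C(=O)C1(C)C` gives 3900 nM
- Compound 2 `CN1c2ccc(NC(=O)Nc3ccc([N+](=O)[O-])cc3)cc2C(C)(C)C(O)C1(C)C` gives 8400 nM
- Compound 3 `CN1c2ccc(NC(=O)Nc3ccc(C(F)(F)F)cc3)cc2C(C)(C)C(O)C1(C)C` gives 6700 nM

All three numbers come from a functional assay on A2780 cells (Homo sapiens) for inhibition, with a stated time of 72 h; on this read-out lower numbers stand for stronger inhibition and higher numbers for weaker inhibition. There, compound 3 at 6700 nM lies within the scatter of both compound 1 and compound 2. Compound 4 `CN1c2ccc(NC(=O)Nc3ccc(OC(F)(F)F)cc3)cc2C(C)(C)C(O)C1(C)C` carries trifluoromethoxy in place of trifluoromethyl on an aromatic carbon. Among the compounds with values here, one measured step bears on this position: trifluoromethyl in place of nitro gave a 1.3-fold lower number from compound 2 to compound 3 (0.10 log units; within the scatter), which is within the scatter. Compound 1 differs from compound 3 in more than one place, so it offers no clean comparison. One small step is thin evidence, but no change beyond the scatter is expected. The expected size is a 1.1-fold lower number from compound 3 to compound 4 (0.05 log units; within the scatter). For compound 4, the estimate in this assay is 6000 nM, with an expected range of 3000 nM to 12000 nM.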

Compound 4, half-maximal inhibitory concentration: 7800 nM
Compound 4: middle estimate off by 1.3-fold (0.11 log units), on the low side; low and high end bracket the measured number.
By their numbers in this assay, from the lowest: compounds 1, 3, 4 and 2 (each within the scatter of the next, the first and the last beyond it).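

In this assay, trifluoromethoxy in place of trifluoromethyl gives a 1.2-fold higher number from compound 3 to compound 4 (0.07 log units; within the scatter), and in place of nitro it gives a 1.1-fold lower number from compound 2 to compound 4 (0.03 log units; within the scatter). This position, on an aromatic carbon para to a large group, has thus carried three different groups with no change beyond the scatter, and the oxygen that trifluoromethoxy adds, with its hydrogen-bond acceptor, brings no readable shift. Nothing measured here offers an explanation for this flat result. Still open, from the compounds shown here alone, is whether an amine, a carboxylic acid or a longer chain at this position would move the number beyond the scatter.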